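The source may report more compounds than this note shows. Statements on the series, on what has been measured and on what is new or still open speak of the compounds shown alone.

In a functional assay on the whole organism (strain Wistar) for inhibition, with Rattus norvegicus as the target, read by paw edema, with stated times of 30 min and 120 min, at a dose of 50 mg/kg by the oral route (a higher number here means more inhibition at the dose given (going by the name of the read-out), a lower number less inhibition), two compounds have been measured. Compound 1, `Cc1ccc(C2=NN(c3ccc([N+](=O)[O-])cc3)C(c3cn(-c4ccccc4)nc3-c3ccc(Cl)c(Cl)c3)C2)cc1`, gives 71.9%, and compound 2, `Clc1ccc(C2=NNC(c3cn(-c4ccccc4)nc3-c3ccc(Cl)c(Cl)c3)C2)cc1`, gives 48.4%. Compound 2 therefore stands lowest of the two, and its nearest neighbour, compound 1, lies higher by a gap that goes beyond the usual scatter of repeated measurements. Compound 3, `O=[N+]([O-])c1ccc(N2N=C(c3ccc(Cl)cc3)CC2c2cn(-c3ccccc3)nc2-c2ccc(Cl)c(Cl)c2)cc1`, has not yet been measured. It differs from compound 2 in one place: 4-nitrophenyl in place of hydrogen on an amine nitrogen in a ring. Compound 1 also carries a 4-nitrophenyl group on the amine nitrogen in its ring, and since compound 1 gives 71.9%, an upward step is expected rather than none. The step from compound 2 to compound 3 in this assay is estimated at a number 18.6 percentage points higher from compound 2 to compound 3 (beyond the scatter). Compound 3 is accordingly expected to give about 67%, with a likely range from 52% to 82%.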

Compound 3, a percentage reported as inhibition, in the whole organism at one dose (the size of the read-out at that dose, not a potency): 69.5%
Compound 3: the middle estimate sits 2.5 percentage points below what was measured; measured number inside the range.
By their numbers in this assay, from the lowest: compound 2; then compounds 3 and 1 (each within the scatter of the next).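

In this assay, 4-nitrophenyl in place of hydrogen on the amine nitrogen in the ring gives a number 21.1 percentage points higher from compound 2 to compound 3 (beyond the scatter). This reads the change at this position directly, which the earlier pair could not do, as compounds 1 and 2 differ in more than one place. With 4-nitrophenyl on that nitrogen, chloro in place of methyl on the aromatic carbon gives a number 2.4 percentage points lower from compound 1 to compound 3 (within the scatter), so that exchange shows no separable change in this pair.

On these data alone, it remains open whether a smaller group on the same nitrogen, such as acetyl or unsubstituted phenyl, or a 4-carboxyphenyl group would give a similar step, and whether chloro and methyl would also match with hydrogen on that nitrogen. What lies behind the step at this position is not explained by any measurement available here.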